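Chain-end exchange in a pyridazinone-bearing series: notes

The compounds below may be only part of what the source reports. "The series", "measured", "known", "first", "only" and "open" are said of these compounds alone.

Compound 1 `N#CNC(=N)NCCCCCn1nc(-c2ccccc2)ccc1=O` is one of two measured members of this series. In a functional assay on the whole organism with Rattus norvegicus as the target, at a dose of 100 mg/kg (a higher number here means more inhibition at the dose given (going by the name of the read-out), a lower number less inhibition), compound 1 gives 31%. Compound 2 `C/N=C(/NC#N)NCCCCCn1nc(-c2ccccc2)c(C)cc1=O` in this assay gives 28.5%; the two numbers lie within the usual scatter of each other, so no order between compound 1 and compound 2 can be read from them. Compound 1 carries the higher of the two numbers, but that is all the data allow.

Compound 3 `N/C(S)=N/CCCCn1nc(-c2ccccc2)ccc1=O` has not been measured. It differs from compound 1 in one place: a group of 4 heavy atoms (1 carbon, 2 nitrogen, 1 sulfur; no ring) in place of a group of 7 heavy atoms (3 carbon, 4 nitrogen; no ring), on a saturated chain carbon, four bonds along the chain from an aromatic nitrogen. For the measured compounds named here, no step between measured compounds separates this change from the rest of the series, so its size is not known from any pair here; the only measured pair, compound 1 and compound 2, shows no difference beyond the scatter.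

Compound 3 is expected to give 26% in this assay, with a range from 10% to 45%. The step of a number 5 percentage points lower from compound 1 to compound 3 (within the scatter) is estimated to stay within the scatter, with a lean towards slightly less inhibition given that the group entering is the smaller of the two.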

Compound 3, a percentage reported as inhibition, in the whole organism at one dose (the size of the read-out at that dose, not a potency): 72%
For compound 3 the middle estimate is 46 percentage points below the measured one; measured number above the stated range.
By their numbers in this assay, from the lowest: compounds 2 and 1 (each within the scatter of the next); then compound 3.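

Notes on the chain end: in this assay, this position proves sensitive to the group it carries, since placing the group of 4 heavy atoms (1 carbon, 2 nitrogen, 1 sulfur; no ring) in place of the group of 7 heavy atoms (3 carbon, 4 nitrogen; no ring), on a saturated chain carbon, gives a number 41 percentage points higher from compound 1 to compound 3 (beyond the scatter). For the compounds shown here, until now, no pair had put a size on any change here, and this pair shows that the smaller entering group is compatible with a clearly higher read-out at this dose. No accompanying measurement speaks to the origin of this step.

On these data alone, one pair cannot separate the contribution of the sulfur from that of the rest of the exchange, so it remains open whether a urea with oxygen in place of the sulfur, a simple amine, or a longer chain carrying the same sulfur-containing end would hold the higher number. The read-out also comes from a single dose, which leaves the dose-response of compound 3 and any potency order open.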